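This account rests on a few compounds, and the source may have more. Where it says the series, first, only, none or still open, it means among the compounds named here.

Working notes on the series. Compound 1 `COc1ccc(CNc2nc([Se]C)nc3ccccc23)cc1` carries methoxy para to a large group on a six-membered aromatic ring of carbon only. In a functional assay on HTB-54 cells (Homo sapiens) for cytotoxicity, read by MTT assay, with a stated time of 72 h (on this read-out lower numbers stand for stronger inhibition of growth and higher numbers for weaker inhibition of growth), compound 1 gives > 100000 nM, which is a limit of the assay and not a number. Compound 3 `COc1ccc(CNc2nc(SC)nc3ccccc23)cc1` gives in this assay > 100000 nM, again a limit. Compound 2 `CCCCC[Se]c1nc([Se]CCCCC)c2ccccc2n1` gives in this assay > 100000 nM, also a limit. Among the measured compounds shown here, the one step between neighbours, a step that the two limits leave unreadable from compound 1 to compound 3, is thus unreadable in size; what the three measurements share is the limit of > 100000 nM in this assay, at which 3 of the 3 values shown sit. Compound 4 `CSc1ccc(CNc2nc([Se]C)nc3ccccc23)cc1` differs from compound 1 by methylsulfanyl in place of methoxy on an aromatic carbon. For the measured compounds named here, no measured step covers this particular change, and the only comparison in hand is the step that the two limits leave without size. Compound 4 is expected to sit at the limit as well, the expected step of a number no higher from compound 1 to compound 4 (the limit leaves the size open) meaning no change beyond the scatter. The estimate for compound 4 in this assay is 100000 nM, with a range from 30000 nM to 300000 nM.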

Compound 4, concentration for total growth inhibition: 72400 nM
Compound 4: the middle estimate sits 1.4-fold (0.14 log units) above what was measured, and the stated range covers the measured number.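

Compound 4 is the only compound shown in this assay with a value that is a number and not a limit, which sets it apart from the rest: the limit of > 100000 nM in this assay, at which 3 of the 4 values shown sit. At this position, para to a large group, methylsulfanyl in place of methoxy gives an at least 1.3-fold lower number from compound 1 to compound 4 (0.14 log units; that floor lies within the scatter). With only a floor to go on, the change is not shown to be real, and the true size of the step remains open.

The other step shown, between compound 1 and compound 3, cannot be read. As far as these compounds go, whether an amine, a carboxylic acid or a longer chain such as ethylsulfanyl at this position would shift the number further stays open, as does whether methylsulfanyl would have any effect on the core of compound 3.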